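Methoxy addition on a triazole pair: a second test

The source may report more compounds than this note shows. Statements on the series, on what has been measured and on what is new or still open speak of the compounds shown alone.

Compound 1 `COc1ccc(-c2ncnn2-c2cc(OC)c(OC)c(OC)c2)cc1` in a functional assay on HL-60 cells (Homo sapiens) for antiproliferative activity, read by MTT assay, with a stated time of 72 h; on this read-out higher numbers stand for weaker inhibition and lower numbers for stronger inhibition: 120 nM
Compound 2 `COc1cc(-c2ncnn2-c2ccccc2)cc(OC)c1OC`: > 10000 nM
Compound 3 `COc1cc(-n2ncnc2-c2ccccc2)cc(OC)c1OC`: > 10000 nM

Compound 3 stops at a limit of this assay. Compound 2 likewise stops at a limit, and the limit of > 10000 nM in this assay, at which 2 of the 3 values shown sit, shows where both sit. The change from compound 3 to compound 1 is methoxy in place of hydrogen on an aromatic carbon, and it brought an at least 83-fold lower number from compound 3 to compound 1 (1.92 log units; beyond the scatter). The difference between the cores of compound 2 and compound 3 is not broken down here. Compound 4 `COc1ccc(-n2ncnc2-c2cc(OC)c(OC)c(OC)c2)cc1` arises from compound 2 by methoxy in place of hydrogen on an aromatic carbon, the same change at the same kind of place. Because compound 1 gives 120 nM, a gain is expected for compound 4 too, though on a different core the expected step is an at least 5.0-fold lower number from compound 2 to compound 4 (0.69 log units; beyond the scatter). Compound 4 is estimated at 2000 nM, between 150 nM and 10000 nM.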

Compound 4, half-maximal inhibitory concentration: 6200 nM
Beside the measured number, compound 4's estimate is 3.1-fold (0.49 log units) below it; the measured number falls inside the stated range.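

In this assay, the change from phenyl to 4-methoxyphenyl brought an at least 1.6-fold lower number from compound 2 to compound 4 (0.20 log units; that floor lies within the scatter), so the gain seen on the other core is not contradicted here, but its floor alone does not establish a gain on this one. Going by these compounds, the value of compound 2, > 10000 nM, is a limit of the assay, so the full size of this step remains unknown. Whether the change does equally well on both cores cannot be decided: the same change on two cores in this assay, an at least 83-fold lower number (1.92 log units; beyond the scatter) from compound 3 to compound 1 and an at least 1.6-fold lower number (0.20 log units; that floor lies within the scatter) from compound 2 to compound 4; the limit leaves it open whether they differ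

The compounds shown leave open whether a group other than methoxy at this place, such as a hydroxyl, an amine or a fluorine, would act alike on the two cores. They also do not separate the two unsubstituted compounds, compound 2 and compound 3: the limit of > 10000 nM in this assay, at which 2 of the 4 values shown sit.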